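The source may hold more compounds than are shown below. What is called first, only, known or untested is meant among the compounds shown, and "the series" means these compounds.

Measured so far in an assay on isolated protein for inhibition of sphingosine 1-phosphate receptor 2 (Homo sapiens); on this read-out lower numbers stand for stronger inhibition and higher numbers for weaker inhibition:
Compound 1, `Cc1cc(CN)cc(C)c1NC(=O)c1ccc(-c2cc(Cl)ccc2Cl)o1`: 3900 nM
Compound 2, `Cc1cc(OCCO)cc(C)c1NC(=O)c1ccc(-c2cc(Cl)ccc2Cl)o1`: 2400 nM

Going by the values given here, on these two numbers compound 2 stands lowest, but the one step so far, a 1.6-fold lower number from compound 1 to compound 2 (0.21 log units; within the scatter), is within the scatter, so the two compounds cannot be told apart. Compound 3, `COc1cc(C)c(NC(=O)c2ccc(-c3cc(Cl)ccc3Cl)o2)c(C)c1`, differs from compound 2 by hydrogen in place of hydroxymethyl on a saturated chain carbon bound to an oxygen on an aromatic ring. Among the compounds with values here, no measured step bears on this change: the single step exchanged one side group for another on the aromatic ring rather than shortening a chain. With nothing to build on, the expected step is none beyond the scatter, a 1.0-fold higher number from compound 2 to compound 3 (0.02 log units; within the scatter). Compound 3 is therefore estimated at 2500 nM, in a range from 900 nM to 7000 nM.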

Compound 3, half-maximal inhibitory concentration: 2800 nM
Estimate against measurement, compound 3: 1.1-fold (0.05 log units) below; measured number inside the range.
By their numbers in this assay, from the lowest: compounds 2, 3 and 1 (each within the scatter of the next).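

In this assay, methoxy and 2-hydroxyethoxy cannot be told apart (a 1.2-fold higher number from compound 2 to compound 3 (0.07 log units; within the scatter)), so on these numbers the hydroxymethyl end of the chain makes no readable difference. Methoxy and aminomethyl on the aromatic carbon cannot be told apart either (a 1.4-fold lower number from compound 1 to compound 3 (0.14 log units; within the scatter)). No supporting measurement is available to explain these results.

On these data alone, it remains open whether a carboxylic acid or a longer chain on this aromatic carbon would give a number beyond the scatter. As far as these compounds go, it also remains open whether any group at this place can separate compounds in this read-out.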